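Indole Thioethers: Chloro for Methoxy and Cell Tolerance

The compounds below may be only part of what the source reports. "The series", "measured", "known", "first", "only" and "open" are said of these compounds alone.

Measured compounds:
compound 1, `O=C(CSc1c[nH]c2cccc(Cl)c12)Nc1ccc(Cl)c(Cl)c1`, 34700 nM
compound 2, `CCOc1ccccc1NC(=O)CSc1c[nH]c2ccc(OC)cc12`, > 100000 nM
compound 3, `COc1cccc2[nH]cc(SCC(=O)Nc3ccc(Cl)c(Cl)c3)c12`, > 100000 nM

In an ADME assay on HEK-293T cells (Homo sapiens) for cytotoxicity, read by CCK-8 assay, with a stated time of 48 h (a higher number here means that more compound is tolerated, a lower number that less compound is tolerated), compound 1 gives 34700 nM. For compound 3 the result in this assay is a limit of the assay, > 100000 nM. For compound 2 the result in this assay is likewise a limit, > 100000 nM. Both limits lie at the limit of > 100000 nM in this assay, at which 2 of the 3 values shown sit. The difference between the cores of compound 2 and compound 3 is not broken down here.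

Compound 3 and compound 1 differ by chloro in place of methoxy on an aromatic carbon. That step gave an at least 2.8-fold lower number from compound 3 to compound 1 (0.45 log units; beyond the scatter).

Compound 4, `CCOc1ccccc1NC(=O)CSc1c[nH]c2ccc(Cl)cc12`, has not yet been measured. It differs from compound 2 by chloro in place of methoxy on an aromatic carbon. This is the same kind of change as from compound 3 to compound 1, but the place is not the same: in compound 4 the chloro sits meta and para to the fused ring, whereas in compound 1 it sits ortho and meta to it. Resting on the earlier step of an at least 2.8-fold lower number from compound 3 to compound 1 (0.45 log units; beyond the scatter), the step from compound 2 to compound 4 in this assay is expected to be an at least 2.0-fold lower number from compound 2 to compound 4 (0.30 log units; that floor lies within the scatter). Compound 4 is therefore estimated at 50000 nM in this assay, with a range from 20000 nM to 150000 nM.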

Compound 4, half-maximal cytotoxic concentration: 37600 nM
Estimate against measurement, compound 4: 1.3-fold (0.12 log units) above; measured number inside the range.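

In this assay, chloro in place of methoxy on an aromatic carbon again gives a lower number, with an at least 2.6-fold lower number from compound 2 to compound 4 (0.42 log units; beyond the scatter), so the direction of the earlier step is seen on a second core, even though the place of the change is not the same. This rests on two pairs only, and the two steps are known only as floors, so their sizes cannot be ranked: the same change on two cores in this assay, an at least 2.8-fold lower number (0.45 log units; beyond the scatter) from compound 3 to compound 1 and an at least 2.6-fold lower number (0.42 log units; beyond the scatter) from compound 2 to compound 4; the limit leaves it open whether they differ. Both steps start from a limit of the assay, so neither shows the full size of the change: the limit of > 100000 nM in this assay, at which 2 of the 4 values shown sit.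

The compounds shown leave open what true values lie behind the limits of compound 2 and compound 3, and whether the step would hold on a third core. They also leave open whether fluoro, a nitrile or a carboxylic acid in place of the methoxy would lower the number in this assay as chloro does.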